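The source may hold more compounds than are shown below. What is called first, only, known or untested is meant among the compounds shown, and "the series" means these compounds.

Three measured compounds share a core and are distinguished by the groups at two ends. Compound 1 `N#Cc1ncc(N2C(=O)C3(CCC3)N(c3ccc(OC4CCNCC4)cc3)C2=S)cc1Cl` in an ADME assay on the whole organism (Mus musculus, strain CD1) for pharmacokinetics, at a dose of 2 mg/kg by the intravenous route (on this read-out lower numbers stand for narrower distribution and higher numbers for wider distribution into tissues), gives 8.47 L/kg. Compound 2 `Cc1cc(N2C(=O)C3(CCC3)N(c3ccc(OC4CCNCC4)nc3)C2=S)cnc1C#N` in this assay gives 4.35 L/kg. Compound 3 `N#Cc1ncc(N2C(=O)C3(CCC3)N(c3ccc(CN4CCNCC4)cc3)C2=S)cc1C(F)(F)F` in this assay gives 16.8 L/kg. Compound 3 thus sits at the upper end of the three numbers, yet its separation from compound 1 falls within the usual scatter of repeated measurements, so no order between those two can be read, while its separation from compound 2 lies beyond the scatter.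

Compound 4 `CN1CCC(Oc2ccc(N3C(=S)N(c4cnc(C#N)c(C(F)(F)F)c4)C(=O)C34CCC4)cc2)CC1` has not yet been measured. It differs from compound 3 in one place: (1-methylpiperidin-4-yl)oxy in place of (piperazin-1-yl)methyl on an aromatic carbon.

Among the compounds with values here, no measured pair isolates this change, so the expectation rests on the values of compound 1, compound 2 and compound 3 alone. The step of a 1.4-fold lower number from compound 3 to compound 4 (0.15 log units; within the scatter) is expected to stay within the usual scatter, leaning if anything toward a narrower distribution. Compound 4 is therefore estimated at 12 L/kg, with a range from 6 L/kg to 24 L/kg.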

Compound 4, volume of distribution at steady state: 12 L/kg
For compound 4 middle estimate and measured number coincide at the digits printed; measured number inside the range.
By their numbers in this assay, from the lowest: compounds 2, 1, 4 and 3 (each within the scatter of the next, the first and the last beyond it).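

Within the data shown here, the change of (piperazin-1-yl)methyl to (1-methylpiperidin-4-yl)oxy on this aromatic carbon, para to a large group, is the first single-place comparison in this assay, and it gives a 1.4-fold lower number from compound 3 to compound 4 (0.15 log units; within the scatter). At this position, then, the two groups cannot be told apart on this read-out, although they differ in ring, linking atom and hydrogen-bond donor count. Nothing measured here accounts for this result.

The compounds shown leave open whether a morpholine, a carboxylic acid or a longer chain at this place would shift the distribution beyond the scatter. They also leave open whether the methyl on the piperidine nitrogen matters, and whether the two groups would stay this close with a chloro or methyl group in place of trifluoromethyl at the other end.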